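This account rests on a few compounds, and the source may have more. Where it says the series, first, only, none or still open, it means among the compounds named here.

Series notes. For the measured compounds named here, in a functional assay on HeLa cells (Homo sapiens) for cytotoxicity, read by neutral red uptake, with a stated time of 3 days (on this read-out higher numbers stand for weaker inhibition and lower numbers for stronger inhibition), compound 1 `COc1c(F)c(N)c2c(=O)cc(-c3ccc(N)c(F)c3)oc2c1F` gives 34000 nM, the only number in the set. Compound 2 `Nc1ccc(-c2cc(=O)c3c(N)c(F)c(Cl)c(F)c3o2)cc1F` returns a limit of > 100000 nM in this assay. Compound 3 `CCOC(=O)c1c(F)c(N)c2c(=O)cc(-c3ccc(N)c(F)c3)oc2c1F` likewise returns a limit of > 100000 nM. Going by the values given here, two measured steps bear on the new compound: an at least 2.9-fold higher number from compound 1 to compound 2 (0.46 log units; beyond the scatter) and an at least 2.9-fold higher number from compound 1 to compound 3 (0.46 log units; beyond the scatter), both replacing the methoxy group and both ending at the limit of > 100000 nM in this assay, at which 2 of the 3 values shown sit. Between the two limits, a step that the two limits leave unreadable from compound 2 to compound 3. Compound 4 `CN(C)Cc1c(F)c(N)c2c(=O)cc(-c3ccc(N)c(F)c3)oc2c1F` is not yet measured; its change from compound 1 is (dimethylamino)methyl in place of methoxy on an aromatic carbon. Both measured replacements of this methoxy gave weaker inhibition, so for compound 4 a higher number is expected, a 2.9-fold higher number from compound 1 to compound 4 (0.47 log units; beyond the scatter), possibly a limit. Compound 4 is estimated at 100000 nM, between 40000 nM and 300000 nM.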

Compound 4, half-maximal inhibitory concentration: 8900 nM
Compound 4: middle estimate off by 11-fold (1.05 log units), on the high side; measured number below the stated range.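

The methoxy position does not only tolerate changes that weaken inhibition: (dimethylamino)methyl gives a 3.8-fold lower number from compound 1 to compound 4 (0.58 log units; beyond the scatter), the only replacement shown that lowers the number. The same group also stands well apart from the chloro and ethoxycarbonyl replacements, with an at least 11-fold lower number from compound 2 to compound 4 (1.05 log units; beyond the scatter) and an at least 11-fold lower number from compound 3 to compound 4 (1.05 log units; beyond the scatter). Compound 2 and compound 3 each give only a limit, so both of these steps are minimum sizes: the limit of > 100000 nM in this assay, at which 2 of the 4 values shown sit.

The step between compound 2 and compound 3 cannot be read. As far as these compounds go, whether the amine nitrogen is what matters stays open; an aminomethyl, a diethylaminomethyl or a carboxylic acid here would bear on that.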